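A few compounds are considered here, and "the series" means these few. Any claim that something is new, unique, unknown or untested is made for them only; others in the source may bear on it.

Compound 1 `CC(C)c1ccc(OC(C)(Cc2cccc(C(F)(F)F)c2)C(=O)O)cc1`: 5 mg/kg
Compound 2 `Cc1cccc(CC(C)(Oc2ccc(C(C)C)cc2)C(=O)O)c1`: < 1 mg/kg
Compound 3 `CCCCc1cccc(CC(C)(Oc2ccc(C(C)C)cc2)C(=O)O)c1`: 1 mg/kg

All three were tested in a functional assay on the whole organism for inhibition, with Rattus norvegicus as the target; on this read-out lower numbers stand for an effect already at smaller amounts and higher numbers for an effect only at larger amounts of compound. Going by these compounds, for compound 2 the read-out < 1 mg/kg is only a limit of the assay, not a number, so its exact place among the others stays open (the limit of < 1 mg/kg in this assay, at which 1 of the 3 values shown sits). Compound 4 `COc1ccc(CC(C)(Oc2ccc(C(C)C)cc2)C(=O)O)cc1` has not been measured. It differs from compound 2 by 4-methoxyphenyl in place of 3-methylphenyl on a saturated chain carbon, two bonds along the chain from a carbonyl carbon and an oxygen on an aromatic ring. The measured steps concern another part of the molecule: an at least 5.0-fold lower number from compound 1 to compound 2 (0.69 log units; beyond the scatter) and a 5.0-fold lower number from compound 1 to compound 3 (0.70 log units; beyond the scatter) both gave lower numbers, while a number no lower from compound 2 to compound 3 (the limit leaves the size open) leaves its size unreadable. None of them alters the part changed in compound 4, so only a small step in either direction is expected, an at least 1.5-fold higher number from compound 2 to compound 4 (0.17 log units; that floor lies within the scatter). Compound 4 is therefore estimated at 1.5 mg/kg, with a range from 0.5 mg/kg to 5 mg/kg.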

Compound 4, dose for half-maximal effect: > 10 mg/kg
Compound 4 was reported as a limit (the forecaster's own chance of this, stated with the estimate: 30%); middle value at least 6.6-fold (0.82 log units) from the limit.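

In this assay, 4-methoxyphenyl in place of 3-methylphenyl gives an at least 10-fold higher number from compound 2 to compound 4 (1.00 log units; beyond the scatter), so this swap on the ring matters at least as much as the earlier ones, which only changed the group on the ring of compound 1. The value of compound 4 is only a limit: the limit of > 10 mg/kg in this assay, at which 1 of the 4 values shown sits. The value of compound 2 is also only a limit: the limit of < 1 mg/kg in this assay, at which 1 of the 4 values shown sits.

This swap changes both the group on the ring and the name's ring position, so the compounds shown cannot tell which of the two carries the step. Plain phenyl on this chain carbon stays open as a reference point.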